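The source may hold more compounds than are shown below. What is called first, only, known or untested is meant among the compounds shown, and "the series" means these compounds.

Compound 3, `COc1cc(CC(O)c2ccc(-c3ccc(F)cc3)cc2)c([N+](=O)[O-])cc1OC`, is the starting point. In an ADME assay on HeLa Rh cells (Homo sapiens) for cytotoxicity, read by microscopy (on this read-out higher numbers stand for lower toxicity in this test and lower numbers for higher toxicity in this test), compound 3 gives 4500 nM. Its closest companion among the measured compounds is compound 1, `COc1cc(CC(O)c2ccc(-c3ccc(C(F)(F)F)cc3)cc2)c([N+](=O)[O-])cc1OC`, which in this assay gives 4100 nM; the step of a 1.1-fold higher number from compound 1 to compound 3 (0.04 log units; within the scatter) lies within the scatter, so the two numbers cannot be told apart. Compound 2, `COc1ccc(-c2ccc(C(O)Cc3cc(OC)c(OC)cc3[N+](=O)[O-])cc2)cc1`, reaches in this assay only a limit of the assay, > 244000 nM. The steps of an at least 59-fold higher number from compound 1 to compound 2 (1.77 log units; beyond the scatter) and an at least 54-fold lower number from compound 2 to compound 3 (1.73 log units; beyond the scatter) are large, and both rest on (the limit of > 244000 nM in this assay, at which 1 of the 3 values shown sits).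

Compound 4, `COc1cc(CC(O)c2ccc(-c3cccc([N+](=O)[O-])c3)cc2)c([N+](=O)[O-])cc1OC`, differs from compound 3 in one place: 3-nitrophenyl in place of 4-fluorophenyl on an aromatic carbon. Within the data shown here, none of the measured steps puts a nitrophenyl onto the shared core, so they bear on this change only loosely: exchanging fluoro for trifluoromethyl gave a 1.1-fold higher number from compound 1 to compound 3 (0.04 log units; within the scatter), within the scatter, whereas exchanging it for methoxy gave an at least 54-fold lower number from compound 2 to compound 3 (1.73 log units; beyond the scatter), far beyond it. For compound 4 a modest rise in this assay is expected, as the step of a 1.8-fold higher number from compound 3 to compound 4 (0.25 log units; within the scatter). The estimate for compound 4 in this assay is 8000 nM, with a range from 2500 nM to 60000 nM.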

Compound 4, half-maximal cytotoxic concentration: 5500 nM
For compound 4 the middle estimate is 1.5-fold (0.16 log units) above the measured one, within the range that was stated.
By their numbers in this assay, from the lowest: compounds 1, 3 and 4 (each within the scatter of the next). At a limit, above all of these: compound 2.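

In this assay, 3-nitrophenyl now joins 4-fluorophenyl and 4-(trifluoromethyl)phenyl as a third group at this position that cannot be told apart from the others, with the steps of a 1.2-fold higher number from compound 3 to compound 4 (0.09 log units; within the scatter) and a 1.3-fold higher number from compound 1 to compound 4 (0.13 log units; within the scatter). The result therefore widens the set of groups that give numbers within the scatter of one another to one that carries a nitro group, which has hydrogen-bond acceptors that 4-fluorophenyl lacks. The 4-methoxyphenyl group remains the one exception among the four, with an at least 44-fold lower number from compound 2 to compound 4 (1.64 log units; beyond the scatter), a large step that rests on a limit of the assay: the limit of > 244000 nM in this assay, at which 1 of the 4 values shown sits.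

From the compounds shown here alone, whether a phenyl ring carrying an amine or a hydroxyl group would match 4-methoxyphenyl or the other three stays open. The numbers also do not say what sets 4-methoxyphenyl apart.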